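Moving the amine along the chain in a GPR88 agonist series

The source may hold more compounds than are shown below. What is called first, only, known or untested is meant among the compounds shown, and "the series" means these compounds.

Measured so far:
compound 1, `CC(C)C[C@H](N)CN(C(=O)[C@@H]1C[C@H]1c1ccccc1)c1ccc(-c2ccccc2)cc1`: 880 nM
compound 2, `CC(C)(C)[C@H](N)CN(C(=O)[C@@H]1C[C@H]1c1ccccc1)c1ccc(-c2ccccc2)cc1`: 11 nM

For the measured compounds named here, in a functional assay for agonist activity at G protein-coupled receptor 88 (Homo sapiens), read by HTRF and cAMP accumulation (a higher number here means that more compound is needed for the effect, a lower number that less compound is needed), compound 1 gives the higher of the two numbers; the only measured step, an 80-fold lower number from compound 1 to compound 2 (1.90 log units; beyond the scatter), shows that the amine-bearing carbon is sensitive to change. Compound 3, `O=C([C@@H]1C[C@H]1c1ccccc1)N(CCNCC1CCCC1)c1ccc(-c2ccccc2)cc1`, differs from compound 1 by ((cyclopentylmethyl)amino)methyl in place of 1-amino-3-methylbutyl on a saturated chain carbon bound to an amide-type nitrogen; the same difference, cut one bond further out, reads 2-amino-4-methylpentyl to 2-((cyclopentylmethyl)amino)ethyl. Going by the values given here, no measured step covers this change, so the expectation is weak. For compound 3 a step of a 1.7-fold higher number from compound 1 to compound 3 (0.23 log units; within the scatter) is estimated, giving 1500 nM with a range of 300 nM to 8000 nM.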

Compound 3, half-maximal effective concentration: 2.5 nM
Beside the measured number, compound 3's estimate is 600-fold (2.78 log units) above it; measured number below the stated range.
By their numbers in this assay, from the lowest: compound 3; then compound 2; then compound 1.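

On a saturated chain carbon bound to an amide-type nitrogen, this position accepts a much larger change than the first pair showed: ((cyclopentylmethyl)amino)methyl brings a 350-fold lower number from compound 1 to compound 3 (2.55 log units; beyond the scatter) and also a 4.4-fold lower number from compound 2 to compound 3 (0.64 log units; beyond the scatter). The entering group has no defined stereocentre, so among these three compounds the lowest number does not depend on one. Still open, going by these compounds, is whether the cyclopentyl ring or the moved amine nitrogen matters more, as the two change together; a cyclohexylmethyl or isobutyl group on that nitrogen would help separate them. Nothing measured here gives a reason for the gain.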